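Bromo for chloro in compound 4: expectation from compound 3

The source may report more compounds than this note shows. Statements on the series, on what has been measured and on what is new or still open speak of the compounds shown alone.

Measured so far in a functional assay on MDA-MB-468 cells (Homo sapiens) for cytotoxicity, read by sulforhodamine B assay, with a stated time of 48 h; a lower number here means a stronger inhibitor of growth, a higher number a weaker inhibitor of growth:
compound 1 `NC(=S)N/N=C1/C(=O)N(CN2CCN(c3ccnc4cc(Cl)ccc34)CC2)c2cccc(Cl)c21` gives 57600 nM
compound 2 `NC(=S)N/N=C1/C(=O)N(CN2CCN(c3ccnc4cc(Cl)ccc34)CC2)c2cccc(Br)c21` gives 40400 nM
compound 3 `NC(=S)N/N=C1/C(=O)N(CN2CCN(c3ccnc4cc(C(F)(F)F)ccc34)CC2)c2cccc(Cl)c21` gives 23000 nM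

For the measured compounds named here, compound 3 carries the lowest of the three numbers; its gap to compound 2 is within the scatter, and only the step of a 2.5-fold lower number from compound 1 to compound 3 (0.40 log units; beyond the scatter) is beyond it. Compound 4 `NC(=S)N/N=C1/C(=O)N(CN2CCN(c3ccnc4cc(C(F)(F)F)ccc34)CC2)c2cccc(Br)c21` differs from compound 3 in one place: bromo in place of chloro on an aromatic carbon. The same exchange has been made once in this series, and it gave a 1.4-fold lower number from compound 1 to compound 2 (0.15 log units; within the scatter), a change within the scatter. Going by the values given here, no other measured step bears on it. In this assay compound 4 is therefore expected to sit near compound 3, with no step beyond the scatter: the estimate is 18000 nM, expected within 8000 nM to 40000 nM. The expected step is a 1.3-fold lower number from compound 3 to compound 4 (0.11 log units; within the scatter).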

Compound 4, concentration for 50% growth inhibition: 30400 nM
For compound 4 the middle estimate is 1.7-fold (0.23 log units) below the measured one; low and high end bracket the measured number.
By their numbers in this assay, from the lowest: compounds 3, 4, 2 and 1 (each within the scatter of the next, the first and the last beyond it).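

In this assay, bromo in place of chloro now reads on a second core, and a 1.3-fold higher number from compound 3 to compound 4 (0.12 log units; within the scatter) again leaves this position, ortho to a fused ring, without a step beyond the scatter: the same change on two cores in this assay, a 1.4-fold lower number (0.15 log units; within the scatter) from compound 1 to compound 2 and a 1.3-fold higher number (0.12 log units; within the scatter) from compound 3 to compound 4, 1.9-fold (0.28 log units) apart, within the scatter of two such steps

Trifluoromethyl in place of chloro, beyond the scatter on the core of compound 1, gives only a 1.3-fold lower number from compound 2 to compound 4 (0.12 log units; within the scatter) with bromo on the core, yet the two steps do not differ beyond the scatter: the same change on two cores in this assay, a 2.5-fold lower number (0.40 log units; beyond the scatter) from compound 1 to compound 3 and a 1.3-fold lower number (0.12 log units; within the scatter) from compound 2 to compound 4, 1.9-fold (0.28 log units) apart, within the scatter of two such steps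

From the compounds shown here alone, whether an amine or a carboxylic acid at this position would move the number beyond the scatter stays open.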